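From 2,4-Dimethylphenyl to 3,4-Dimethylphenyl on a Carbonyl Carbon

This account rests on a few compounds, and the source may have more. Where it says the series, first, only, none or still open, it means among the compounds named here.

In a functional assay on C8166 cells (Homo sapiens) for cytotoxicity, read by MTT assay (a higher number here means that more compound is tolerated, a lower number that less compound is tolerated), compound 1 `Cc1cccc(C(=O)Nc2cc(Cl)ccc2OCC(=O)Nc2ccc(S(N)(=O)=O)cc2C)c1` gives 52900 nM, compound 2 `Cc1cc(S(N)(=O)=O)ccc1NC(=O)COc1ccc(Cl)cc1NC(=O)c1cccc([N+](=O)[O-])c1` gives 58800 nM, and compound 3 `Cc1ccc(C(=O)Nc2cc(Cl)ccc2OCC(=O)Nc2ccc(S(N)(=O)=O)cc2C)c(C)c1` gives 47600 nM. Compound 3 thus stands level with the other two, within the scatter of both.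

Compound 4 `Cc1ccc(C(=O)Nc2cc(Cl)ccc2OCC(=O)Nc2ccc(S(N)(=O)=O)cc2C)cc1C` carries 3,4-dimethylphenyl in place of 2,4-dimethylphenyl on a carbonyl carbon. Among the measured compounds shown here, the two have the same atoms, joined differently, and no measured step makes this exact exchange. The closest evidence comes from two changes at the same place: a 1.1-fold lower number from compound 1 to compound 3 (0.05 log units; within the scatter), and a 1.2-fold lower number from compound 2 to compound 3 (0.09 log units; within the scatter). The nitro for methyl exchange, a 1.1-fold higher number from compound 1 to compound 2 (0.05 log units; within the scatter), bears on it as well. All three steps lie within the scatter, so nothing in these three compounds points to a real shift in either direction. No step beyond the scatter is therefore expected in this assay.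

The expected change is small, an estimated 1.1-fold higher number from compound 3 to compound 4 (0.02 log units; within the scatter). Compound 4 is estimated at 50000 nM, with an expected range of 29000 nM to 85000 nM.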

Compound 4, half-maximal cytotoxic concentration: 84100 nM
The estimate for compound 4 lay 1.7-fold (0.23 log units) below the measured number; low and high end bracket the measured number.
By their numbers in this assay, from the lowest: compounds 3, 1, 2 and 4 (each within the scatter of the next).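

In this assay, exchanging 2,4-dimethylphenyl for 3,4-dimethylphenyl on a carbonyl carbon, with the same atoms joined differently, gives a 1.8-fold higher number from compound 3 to compound 4 (0.25 log units; within the scatter), the largest step among these compounds so far but still not a real shift. The other two new steps agree: adding one methyl gives a 1.6-fold higher number from compound 1 to compound 4 (0.20 log units; within the scatter), and replacing 3-nitrophenyl with 3,4-dimethylphenyl gives a 1.4-fold higher number from compound 2 to compound 4 (0.16 log units; within the scatter), so all four groups at this position remain level, even with both methyl placements and a nitro group now covered. Nothing available gives a reason for the size of the step between these two dimethylphenyl groups.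

Every group shown here on this carbonyl carbon is a substituted phenyl, so it remains open whether a cyclohexyl or pyridyl group would also stay level in this assay. From the compounds shown here alone, a carboxylic acid or an amine on the phenyl ring is equally open.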